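The source may report more compounds than this note shows. Statements on the series, on what has been measured and on what is new or still open speak of the compounds shown alone.

Compound 3 `Cc1cccc2oc(-c3cccc(C[C@H](O)/C=C/[C@H]4CCC(=O)N4CCSc4nc(C(=O)O)cs4)c3)nc12` gives 7700 nM in an assay on CHO cells for displacement of a labelled ligand from prostaglandin E2 receptor EP1 subtype (Mus musculus), read by scintillation counting, with a stated time of 20 min (a higher number here means a weaker inhibitor, a lower number a stronger inhibitor), and stands within the usual scatter of compound 1 `O=C(O)c1csc(SCCN2C(=O)CC[C@@H]2/C=C/[C@@H](O)Cc2cccc(-c3ccc(Cl)cc3)c2)n1`, which gives 6300 nM in this assay. Compound 2 `O=C(O)c1csc(SCCN2C(=O)CC[C@@H]2/C=C/[C@@H](O)Cc2cccc(-c3nc4ccccc4o3)c2)n1` reaches only the limit of this assay, > 10000 nM, as noted in the limit of > 10000 nM in this assay, at which 1 of the 3 values shown sits. Compound 4 `Cc1cc(C)c2oc(-c3cccc(C[C@H](O)/C=C/[C@H]4CCC(=O)N4CCSc4nc(C(=O)O)cs4)c3)nc2c1` differs from compound 3 by 5,7-dimethyl-1,3-benzoxazol-2-yl in place of 4-methyl-1,3-benzoxazol-2-yl on an aromatic carbon. Among the measured compounds shown here, the one measured step on this ring, methyl in place of hydrogen, gave an at least 1.2-fold lower number from compound 2 to compound 3 (0.11 log units; that floor lies within the scatter), a floor within the scatter, and a 1.2-fold higher number from compound 1 to compound 3 (0.09 log units; within the scatter) was also within the scatter. For the measured compounds named here, no measured step adds two methyls, so no step beyond the scatter is expected in this assay, and the expected step is a 1.1-fold lower number from compound 3 to compound 4 (0.04 log units; within the scatter). Compound 4 is therefore estimated at 7000 nM, within 2500 nM to 20000 nM.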

Compound 4, inhibition constant: 3200 nM
For compound 4 the middle estimate is 2.2-fold (0.34 log units) above the measured one; measured number inside the range.
By their numbers in this assay, from the lowest: compounds 4, 1 and 3 (each within the scatter of the next, the first and the last beyond it). At a limit, above all of these: compound 2.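

Among the compounds shown here, on this aromatic carbon, 5,7-dimethyl-1,3-benzoxazol-2-yl gives the first step beyond the scatter among the benzoxazoles in this assay, a 2.4-fold lower number from compound 3 to compound 4 (0.38 log units; beyond the scatter), and an at least 3.1-fold lower number from compound 2 to compound 4 (0.49 log units; beyond the scatter) also lies beyond it. Compound 2 is held at a limit, not a number: the limit of > 10000 nM in this assay, at which 1 of the 4 values shown sits. The comparison with 4-chlorophenyl separates nothing: a 2.0-fold lower number from compound 1 to compound 4 (0.29 log units; within the scatter).

Which of the two methyls carries the step stays open. So does the effect of a methoxy group or an amine on this ring.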